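A few compounds are considered here, and "the series" means these few. Any claim that something is new, unique, unknown or untested is made for them only; others in the source may bear on it.

Measured in a functional assay on HCT-116 cells (Homo sapiens) for inhibition; a higher number here means that more compound is needed for the effect, a lower number that less compound is needed:
- compound 1 `COc1cc(N2CCN(C(=O)N3CCN(C)CC3)CC2)ccc1Nc1nc(NC2CCCCC2)c2nc[nH]c2n1`: 18 nM
- compound 2 `COc1cc(N2CCN(CC3CCOC3)CC2)ccc1Nc1nc(NC2CCCCC2)c2nc[nH]c2n1`: 170 nM
- compound 3 `COc1cc(N2CCC(C(=O)N3CCOCC3)CC2)ccc1Nc1nc(NC2CCCCC2)c2nc[nH]c2n1`: 130 nM

Compound 3, at 130 nM, lies within the scatter of compound 2, at 170 nM. Compared with compound 3, compound 1 has a clearly lower number, at 18 nM.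

Next is compound 4 `COc1cc(N2CCC(CC(=O)N3CCN(C)CC3)CC2)ccc1Nc1nc(NC2CCCCC2)c2nc[nH]c2n1`, which differs from compound 3 as follows: ((4-methylpiperazin-1-yl)carbonyl)methyl in place of (morpholin-4-yl)carbonyl on a saturated ring carbon. In words, ((4-methylpiperazin-1-yl)carbonyl)methyl takes the place of (morpholin-4-yl)carbonyl on a saturated ring carbon.

Within the data shown here, no measured pair shows this exact change. The nearest evidence is a 9.4-fold higher number from compound 1 to compound 2 (0.98 log units; beyond the scatter), where (oxolan-3-yl)methyl replaces (4-methylpiperazin-1-yl)carbonyl on an amine nitrogen in a ring. That is a single step, with a different partner group and a different attachment, so it transfers only in part. A lower number in this assay is expected, by a smaller step than that one.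

The estimate means a 2.6-fold lower number from compound 3 to compound 4 (0.41 log units; beyond the scatter), an expected change. Compound 4 is expected at 50 nM, with an estimated range of 15 nM to 150 nM.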

Compound 4, half-maximal effective concentration: 65 nM
Compound 4: middle estimate off by 1.3-fold (0.11 log units), on the low side; measured number inside the range.
By their numbers in this assay, from the lowest: compound 1; then compounds 4, 3 and 2 (each within the scatter of the next, the first and the last beyond it).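

Working notes: in this assay, the step on the saturated ring carbon, a 2.0-fold lower number from compound 3 to compound 4 (0.30 log units; within the scatter), shows that this position accepts ((4-methylpiperazin-1-yl)carbonyl)methyl in place of (morpholin-4-yl)carbonyl with no change that can be read beyond the scatter. Among these compounds, this exchange alters two things at once, the ring on the carbonyl and the added methylene link, and the single step cannot separate them or show whether their separate effects are small or offset each other. Nothing available gives a reason for this result.

Open, as far as these compounds go, is how the ((morpholin-4-yl)carbonyl)methyl group would read at this same ring carbon, as it carries the link without the change of ring. Also open, from the compounds shown here alone, is whether a free carboxylic acid or a longer chain to the amide would hold there.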